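From an Aromatic Ring to a Saturated Ring at the Amine

The source may report more compounds than this note shows. Statements on the series, on what has been measured and on what is new or still open speak of the compounds shown alone.

Compound 2 `CCOc1ccc(NC2=CC(=O)c3c(nc4n3[C@H]3OC[C@@H](O)[C@H]3OC4)C2=O)cc1` stands at the highest number of the two measured; in a functional assay on HeLa cells (Homo sapiens) for inhibition, read by sulforhodamine B assay (a lower number here means a stronger inhibitor, a higher number a weaker inhibitor), compound 2 gives 14400 nM. Its nearest neighbour, compound 1 `O=C1C=C(Nc2ccc(I)cc2)C(=O)c2c1nc1n2[C@H]2OC[C@@H](O)[C@H]2OC1`, gives 4070 nM in this assay, a gap beyond the usual scatter. Compound 3 `O=C1C(NC2CCCCC2)=CC(=O)c2c1nc1n2[C@H]2OC[C@@H](O)[C@H]2OC1` differs from compound 2 in one place: cyclohexyl in place of 4-ethoxyphenyl on an amine nitrogen. Among the measured compounds shown here, no measured pair shows such a change, so its size is unknown; the expected step in this assay is none beyond the scatter. Compound 3 is expected to give 15000 nM, within 5000 nM to 45000 nM. That expectation means a step of a 1.0-fold higher number from compound 2 to compound 3 (0.02 log units; within the scatter).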

Compound 3, half-maximal inhibitory concentration: > 16000 nM
Compound 3: no number, only a limit (the forecaster's own chance of this, stated with the estimate: 10%); at least 1.0-fold (0.02 log units) between middle value and limit.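

In this assay compound 3 carries only a limit, > 16000 nM, and no number. Cyclohexyl in place of 4-ethoxyphenyl on an amine nitrogen gives an at least 1.1-fold higher number from compound 2 to compound 3 (0.04 log units; that floor lies within the scatter), so the saturated ring did not lower the number, while how far it raised it, if at all, stays unread. The size of this step is hidden because the reading stops at a limit: the limit of > 16000 nM in this assay, at which 1 of the 3 values shown sits.

The compounds shown leave open whether cyclopentyl or an open n-hexyl chain on the same nitrogen would read under that limit. They also leave open whether a cyclohexyl ring carrying a hydroxyl would do so.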